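Swapping the Trifluoromethyl Ketone for a Dimethylamide

The compounds below may be only part of what the source reports. "The series", "measured", "known", "first", "only" and "open" are said of these compounds alone.

In an assay on HEK-293T cells for inhibition of diacylglycerol lipase-alpha (Homo sapiens), read by colorimetric assay (on this read-out lower numbers stand for stronger inhibition and higher numbers for weaker inhibition), compound 1 `O=C(CCCCCc1ccccc1)c1nc2ccc(F)cc2o1` gives 708 nM. For the measured compounds named here, compound 2 `O=C(CCCCCCc1ccccc1)c1nc(C(=O)C(F)(F)F)co1` gives 123 nM in this assay, the lowest of the two numbers measured so far; compound 1 stands at a higher number, and the gap between them lies beyond the usual scatter. Compound 3 `CN(C)C(=O)c1coc(C(=O)CCCCCCc2ccccc2)n1` has not yet been measured in this assay. It differs from compound 2 by dimethylamino in place of trifluoromethyl on a carbonyl carbon, so that the (trifluoromethyl)carbonyl of compound 2 becomes a dimethylcarbamoyl. Going by the values given here, no measured pair shows this change, so nothing beyond the two values above anchors the size of the step; the account nonetheless expects a move to a weaker compound, beyond the scatter, with an estimated step of a 20-fold higher number from compound 2 to compound 3 (1.31 log units; beyond the scatter) in this assay. Compound 3 is accordingly estimated at 2500 nM in this assay, with an expected range from 500 nM to 12000 nM.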

Compound 3, half-maximal inhibitory concentration: 3390 nM
The estimate for compound 3 lay 1.4-fold (0.13 log units) below the measured number; the range from low to high includes it.
By their numbers in this assay, from the lowest: compound 2; then compound 1; then compound 3.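

In this assay, for the compounds shown here, putting dimethylamino in place of trifluoromethyl on the carbonyl carbon gives a 28-fold higher number from compound 2 to compound 3 (1.44 log units; beyond the scatter), a large step and the first pair that isolates a change at this place. With the rest of compound 2 left as it stands, this pair shows that the (trifluoromethyl)carbonyl cannot be exchanged for a dimethylcarbamoyl without a clear weakening of inhibition. Nothing available explains the size of this step.

As far as these compounds go, it remains open whether the weakening follows from the arrival of dimethylamino or the departure of trifluoromethyl; a methyl ketone, a primary amide, a methyl ester or a carboxylic acid on the same carbonyl carbon would help separate the two. A single pair also leaves open whether a step of this size would hold with a shorter chain or on the core of compound 1.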